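Swapping an amine chain for a pyridine on the amide nitrogen

A few compounds are considered here, and "the series" means these few. Any claim that something is new, unique, unknown or untested is made for them only; others in the source may bear on it.

Three compounds share one core and were tested in a functional assay on CHO-RD-HGA16 cells for agonist activity at Orexin/Hypocretin receptor type 1 (Homo sapiens), read by fluorescence and calcium flux, with a stated time of 30 min; on this read-out higher numbers stand for an effect only at larger amounts of compound and lower numbers for an effect already at smaller amounts. Compound 1 `COc1ccc(-c2csc(C(=O)N(C)C)c2)cc1S(=O)(=O)Nc1cccc(NCCNC(=O)c2cccc(C)c2)c1` gives 1330 nM. Compound 2 `COc1ccc(-c2csc(C(=O)N(C)C)n2)cc1S(=O)(=O)Nc1cccc(NCCNC(=O)c2cccc(C)c2)c1` gives 928 nM; the change a 1.4-fold lower number from compound 1 to compound 2 (0.16 log units; within the scatter). Compound 3 `COc1ccc(-c2cccc(C(=O)N(C)CCN(C)C)c2)cc1S(=O)(=O)Nc1cccc(NCCNC(=O)c2cccc(C)c2)c1` gives 638 nM, the lowest of the three numbers, though its gap to compound 2 lies within the scatter and only its gap to compound 1 lies beyond it.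

Compound 4 `COc1ccc(-c2cccc(C(=O)N(C)c3ccccn3)c2)cc1S(=O)(=O)Nc1cccc(NCCNC(=O)c2cccc(C)c2)c1` is not yet measured. It differs from compound 3 by pyridin-2-yl in place of 2-(dimethylamino)ethyl on an amide-type nitrogen. Among the measured compounds shown here, no measured step bears directly on this change: the single measured step concerns a swap of one aromatic ring for another on an aromatic carbon, not the group on the amide nitrogen, and that step stayed within the scatter. With no guidance either way, compound 4 is expected to come out close to compound 3, and the step of a 1.1-fold higher number from compound 3 to compound 4 (0.04 log units; within the scatter) is therefore estimated to stay within the scatter. For compound 4 the estimate in this assay is 700 nM, with a range from 250 nM to 2000 nM.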

Compound 4, half-maximal effective concentration: > 10000 nM
Compound 4 ended at the assay's limit; the forecaster's own chance of this, stated with the estimate: 5%; at least 14-fold (1.15 log units) between middle value and limit.
By their numbers in this assay, from the lowest: compounds 3, 2 and 1 (each within the scatter of the next, the first and the last beyond it). At a limit, above all of these: compound 4.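

Among the compounds shown here, on the amide-type nitrogen, the group matters far more than the earlier compounds could show: in this assay, pyridin-2-yl in place of 2-(dimethylamino)ethyl gives an at least 15-fold higher number from compound 3 to compound 4 (1.19 log units; beyond the scatter), a large step beyond the scatter. For the compounds shown here, the only earlier step, a 1.4-fold lower number from compound 1 to compound 2 (0.16 log units; within the scatter), was a swap of one aromatic ring for another on an aromatic carbon, so this is the first change here to make a clear difference. From the compounds shown here alone, the true size of the new step stays unknown, since compound 4 stands at a limit and not at a number: the limit of > 10000 nM in this assay, at which 1 of the 4 values shown sits.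

Going by these compounds, what stays open is whether the result follows from pyridin-2-yl entering or from 2-(dimethylamino)ethyl leaving. A phenyl ring or a plain ethyl chain on the same nitrogen would help to separate the two.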